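This account rests on a few compounds, and the source may have more. Where it says the series, first, only, none or still open, it means among the compounds named here.

Compound 1 `Cn1ccc2c(Oc3ccc(NC(=O)c4cc5cccnc5n(-c5ccccc5)c4=O)cc3F)ncnc21`: 51800 nM
Compound 2 `Cn1ccc2c(Oc3ccc(NC(=O)c4cc5cccnc5n(-c5ccc(Br)cc5)c4=O)cc3F)ncnc21`: 33800 nM

In a functional assay on HeLa cells (Homo sapiens) for cytotoxicity, read by MTT assay, with a stated time of 72 h (a lower number here means a stronger inhibitor, a higher number a weaker inhibitor), compound 2 gives 33800 nM and compound 1 gives 51800 nM. Within the data shown here, these two values lie within the scatter of each other, so compound 2 does not stand apart from compound 1 on the numbers so far.

The next compound is compound 3 `Cn1ccc2c(Oc3ccc(NC(=O)c4cc5cccnc5n(-c5ccc(C(F)(F)F)c(Cl)c5)c4=O)cc3F)ncnc21`, which carries 3-chloro-4-(trifluoromethyl)phenyl in place of 4-bromophenyl on an aromatic nitrogen. Among the measured compounds shown here, only one measured step bears on this change, namely a 1.5-fold lower number from compound 1 to compound 2 (0.19 log units; within the scatter), made on the same phenyl ring. For the measured compounds named here, that step stays within the scatter, and no measured compound carries the entering group, so no shift beyond the scatter is expected in this assay. The expected step is a 1.1-fold lower number from compound 2 to compound 3 (0.05 log units; within the scatter). For compound 3 the estimate is 30000 nM, with an expected range from 12000 nM to 70000 nM.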

Compound 3, half-maximal inhibitory concentration: 156000 nM
The estimate for compound 3 lay 5.2-fold (0.72 log units) below the measured number, and the stated range ends below it.
By their numbers in this assay, from the lowest: compounds 2 and 1 (each within the scatter of the next); then compound 3.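

Placing 3-chloro-4-(trifluoromethyl)phenyl on the aromatic nitrogen in place of 4-bromophenyl gives a 4.6-fold higher number from compound 2 to compound 3 (0.66 log units; beyond the scatter) in this assay, and placing it there instead of phenyl gives a 3.0-fold higher number from compound 1 to compound 3 (0.48 log units; beyond the scatter). The position is therefore not indifferent to what its phenyl ring carries: unlike the bromo step, both of these steps lie beyond the scatter, and both run towards a weaker inhibitor, though only modestly. Nothing available accounts for this shift.

Since the chloro and trifluoromethyl groups enter together, the compounds shown do not separate their contributions to the step. Going by these compounds, it also remains open how an amine, a carboxylic acid or a methoxy group on this phenyl ring would move the number.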